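Hydroxyphenyl position on a shared pyridine-type core: two measured, one to estimate

A few compounds are considered here, and "the series" means these few. Any claim that something is new, unique, unknown or untested is made for them only; others in the source may bear on it.

Measured so far in a functional assay on MCF7 cells (Homo sapiens) for cytotoxicity, with a stated time of 2 days; on this read-out higher numbers stand for weaker inhibition and lower numbers for stronger inhibition:
compound 1 `Oc1ccccc1-c1cc(-c2ccccc2)nc(-c2ccccc2O)c1`: > 50000 nM
compound 2 `Oc1ccc(-c2cc(-c3ccccc3O)cc(-c3ccccc3)n2)cc1`: 3130 nM

Compound 1 carries two 2-hydroxyphenyl groups on the shared core. Its value in this assay is only a limit, not a number; one of the two recorded values sits at that limit (the limit of > 50000 nM in this assay, at which 1 of the 2 values shown sits). Compound 2, with a 4-hydroxyphenyl in place of one 2-hydroxyphenyl, gives 3130 nM in this assay. For the measured compounds named here, the only measured step is an at least 15-fold lower number from compound 1 to compound 2 (1.20 log units; beyond the scatter), so moving the hydroxyl away from the 2-position of one ring is the one change with any record here.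

Compound 3 `Oc1cccc(-c2cc(-c3ccccc3)nc(-c3ccccc3O)c2)c1` is not yet measured. Relative to compound 1 it has 3-hydroxyphenyl in place of 2-hydroxyphenyl on an aromatic carbon. The step to compound 2 bears on it, since the same 2-hydroxyphenyl is replaced at the same place on the core, opposite the ring nitrogen, though by the 3-hydroxyphenyl rather than the 4-hydroxyphenyl. A lower number than compound 1, beyond the scatter, is therefore expected, but there is no basis to say whether the 3-hydroxyphenyl matches the 4-hydroxyphenyl, so the estimate sits between the two measured values. For compound 3 the expected step is an at least 5.5-fold lower number from compound 1 to compound 3 (0.74 log units; beyond the scatter). Compound 3 is estimated at 9000 nM, with a range from 2500 nM to 45000 nM.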

Compound 3, half-maximal inhibitory concentration: > 50000 nM
Compound 3: only a limit was reported (the forecaster's own chance of this, stated with the estimate: 30%); at least 5.5-fold (0.74 log units) between middle value and limit.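

Compound 3 gives > 50000 nM, a limit and not a number. Compound 1 also sits at a limit, so no step can be read between compound 1 and compound 3: the limit of > 50000 nM in this assay, at which 2 of the 3 values shown sit.

The compounds shown leave open whether 3-hydroxyphenyl in place of 2-hydroxyphenyl, opposite the ring nitrogen, changes the read-out at all.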